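Fluorine removal on the anilide of a carbamate-bearing GIP agonist series

The source may hold more compounds than are shown below. What is called first, only, known or untested is meant among the compounds shown, and "the series" means these compounds.

Measured so far in a functional assay on HEK293 cells for agonist activity at Glucose-dependent insulinotropic receptor (Homo sapiens), read by cAMP accumulation, with a stated time of 60 min; on this read-out lower numbers stand for smaller maximal responses and higher numbers for larger maximal responses:
compound 1, `COc1cc2nc(Nc3ccc(S(C)(=O)=O)cc3)nc(N3CCC4CCC(C3)N4Cc3ccccc3)c2cc1OC`: 32.8%
compound 2, `COc1cc2nc(Nc3ccc(S(C)(=O)=O)cc3F)nc(OCC3CCN(C(=O)OC(C)(C)C)CC3)c2cc1OC`: 21.3%
compound 3, `COc1cc2nc(N3CCC4CCC(C3)N4C(=O)OC(C)(C)C)nc(Nc3ccc(S(C)(=O)=O)cc3F)c2cc1OC`: 56.9%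

Compound 2 gives the lowest of the three values in this assay; compound 1 is the nearest, and compound 3 the furthest, both beyond the scatter. Compound 2 and compound 4 differ only in one place, (hydrogen in place of fluoro on an aromatic carbon). Compound 4, `COc1cc2nc(Nc3ccc(S(C)(=O)=O)cc3)nc(OCC3CCN(C(=O)OC(C)(C)C)CC3)c2cc1OC`, is not yet measured. For the measured compounds named here, no pair of measured compounds differs by this change alone, so its size is unknown here. The step is expected to be small, of the order of the scatter, with a slight rise if any. For compound 4 the estimate in this assay is 27%, in the range 12% to 44%. This estimate means an expected step of a number 5.7 percentage points higher from compound 2 to compound 4 (within the scatter).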

Compound 4, largest response reached (Emax), in percent of the reference or control that the assay uses: 17.4%
Beside the measured number, compound 4's estimate is 9.6 percentage points above it; measured number inside the range.
By their numbers in this assay, from the lowest: compounds 4 and 2 (each within the scatter of the next); then compound 1; then compound 3.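

In this assay, replacing 2-fluoro-4-(methylsulfonyl)phenyl with 4-(methylsulfonyl)phenyl gives a number 3.9 percentage points lower from compound 2 to compound 4 (within the scatter). For the compounds shown here, this is the only pair here that isolates this aromatic carbon, and fluoro and hydrogen cannot be told apart there on maximal response. Nothing available accounts for the size of this step.

Open, going by these compounds, is whether a chloro, methoxy or amine group on this aromatic carbon would give a step beyond the scatter. Also open, on these data alone, is whether the same fluoro-to-hydrogen change stays this small with the other substituent of compound 3.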